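This account rests on a few compounds, and the source may have more. Where it says the series, first, only, none or still open, it means among the compounds named here.

Measured so far in a physicochemical assay for lipophilicity, at pH 7.4; on this read-out lower numbers stand for lower lipophilicity and higher numbers for higher lipophilicity:
compound 1 `CCc1ccc(N(CC(C)C)S(=O)(=O)c2ccc3cc(OCC4CCOCC4)c(CO)cc3c2)cc1` gives 5.1
compound 2 `CCc1ccc(N(CC(C)C)S(=O)(=O)c2ccc3c(c2)C(=O)CC(CC2CCOCC2)O3)cc1` gives 4.53
compound 3 `CCc1ccc2c(c1)CC(C)CN2S(=O)(=O)c1ccc2c(c1)C(=O)CC(C1CCOCC1)O2` gives 3.77

Compound 1 stands highest of the three numbers in this assay. Compound 2 is the nearest, with a value lower by a gap beyond the scatter; compound 3 is the furthest, its value lower by a larger gap, also beyond the scatter. Compound 1 is the reference for the next step.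

Compound 4 `CCc1ccc(N(CC(C)C)S(=O)(=O)c2ccc3cc(OCC4CCOCC4)c(C(=O)OC)cc3c2)cc1` is not yet measured. Its difference from compound 1 is methoxycarbonyl in place of hydroxymethyl on an aromatic carbon, on an aromatic carbon of the fused six-membered ring, ortho to the (oxan-4-yl)methoxy group. The hydroxymethyl with its donor leaves, and the methoxycarbonyl with its acceptors enters.

Among the measured compounds shown here, no measured pair shows this exchange, so the expectation rests on compound 1 alone. From compound 1 a moderate upward step is expected, beyond the scatter: a number 0.60 log units higher from compound 1 to compound 4 (beyond the scatter). Compound 4 is thus estimated at 5.7 in this assay, within a range of 5.2 to 6.2.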

Compound 4, distribution coefficient: 6.09
Compound 4: the middle estimate sits 0.39 log units below what was measured; low and high end bracket the measured number.
By their numbers in this assay, from the lowest: compound 3; then compound 2; then compound 1; then compound 4.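

The pair gives the series its first single-place comparison: in this assay, methoxycarbonyl in place of hydroxymethyl on the aromatic carbon ortho to the (oxan-4-yl)methoxy group gives a number 0.99 log units higher from compound 1 to compound 4 (beyond the scatter) on an otherwise unchanged structure. Among the compounds shown here, the read-out is therefore sensitive to the group at this position, which the earlier compounds, differing in several places at once, could not show. No measurement is at hand to explain the step, and this single exchange changes the heavy-atom, donor and acceptor counts together.

Open, as far as these compounds go, is whether a methoxymethyl group at this position would separate the loss of the hydroxyl hydrogen from the arrival of the carbonyl. Also open, from the compounds shown here alone, is where a carboxylic acid or an aminomethyl group would stand in this assay relative to these two groups.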